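The source may hold more compounds than are shown below. What is called first, only, known or untested is meant among the compounds shown, and "the series" means these compounds.

Two compounds of the series have numbers in a functional assay on HeLa cells (Homo sapiens) for antiproliferative activity, read by MTT assay (on this read-out higher numbers stand for weaker inhibition and lower numbers for stronger inhibition), so far. Compound 1 `Cc1cccc(Nc2nccc(-c3ccc(Br)cc3)n2)c1` gives 71000 nM there. Compound 2 `O=[N+]([O-])c1ccc(Nc2nccc(-c3ccc(Br)cc3)n2)cc1` gives 25700 nM and holds the lower of the two numbers, a gap beyond the usual scatter. The next entry is compound 3 `Clc1ccc(Nc2nccc(-c3ccc(Br)cc3)n2)cc1` which differs from compound 2 at one place: chloro in place of nitro on an aromatic carbon, para to a large group, with chloro in place of nitro on an aromatic carbon as the counted difference. Within the data shown here, no measured step isolates this change. The expectation rests only on compound 2 at 25700 nM and compound 1 at 71000 nM as the two values in hand. In this assay the expected move is small, toward a higher number and not beyond the scatter, with a 1.4-fold higher number from compound 2 to compound 3 (0.13 log units; within the scatter) as the estimated step. Compound 3 is expected at 35000 nM with a range from 12000 nM to 80000 nM in this estimate.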

Compound 3, half-maximal inhibitory concentration: 36700 nM
Estimate against measurement, compound 3: 1.0-fold (0.02 log units) below, and the stated range covers the measured number.
By their numbers in this assay, from the lowest: compounds 2, 3 and 1 (each within the scatter of the next, the first and the last beyond it).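

In this assay the position on the aromatic carbon para to a large group now has its first single-place reading: chloro in place of nitro gives a 1.4-fold higher number from compound 2 to compound 3 (0.15 log units; within the scatter) and so leaves the number within the scatter, although the entering group shares neither the heavy-atom count nor the hydrogen-bond acceptors of the group that leaves. The wider exchange of 4-chlorophenyl in place of 3-methylphenyl on a nitrogen on an aromatic ring gives a 1.9-fold lower number from compound 1 to compound 3 (0.29 log units; within the scatter) and also stays within the scatter, so compound 3 cannot be separated from either neighbour. No supporting data bear on the size of these two steps.

On these data alone, whether an amine or a carboxylic acid at this position would behave like chloro and nitro remains open. Also open, as far as these compounds go, is whether any single-place change can produce a step beyond the scatter.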